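Changing the aryl group on a sulfonyl sulfur

This account rests on a few compounds, and the source may have more. Where it says the series, first, only, none or still open, it means among the compounds named here.

Measured so far in an ADME assay (liver) for metabolic stability, with Liver microsome (Homo sapiens) as the target, read by LC-MS, using microsomes and NADPH, with a stated time of 5 min, at 37 degrees C (a lower number here means slower removal, a higher number faster removal of the compound), for three compounds:
- Compound 1 `CCn1c([C@@H](C)NS(=O)(=O)c2ccc(Cl)cc2)nc2cc(F)c(Cl)cc21` gives > 100 mL.min-1.g-1 as a limit, not a number
- Compound 2 `CCn1c(C(C)NS(=O)(=O)c2ccc(Cl)cc2)nc2cccnc21` gives 94 mL.min-1.g-1 as a number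
- Compound 3 `CCn1c([C@@H](C)NS(=O)(=O)c2cccc(Cl)c2)nc2ccc(C(F)(F)F)cc21` gives > 100 mL.min-1.g-1 as a limit, not a number

Compound 3 has no exact value, and its > 100 mL.min-1.g-1 in this assay is only a limit. That places it at the limit of > 100 mL.min-1.g-1 in this assay, at which 2 of the 3 values shown sit, and leaves no exact starting point. Compound 4 `CCCn1cc(S(=O)(=O)N[C@H](C)c2nc3ccc(C(F)(F)F)cc3n2CC)c(C)n1` differs from compound 3 in one place: a group of 9 heavy atoms (7 carbon, 2 nitrogen; one five-membered aromatic ring with 2 hetero atoms) in place of a group of 7 heavy atoms (6 carbon, 1 chlorine; one six-membered aromatic ring of carbon only), on a sulfonyl sulfur describes the change. For the measured compounds named here, no measured step shows what such a change does. Going by the values given here, compound 2 gives 94 mL.min-1.g-1 as the only exact number, so fast removal is expected to persist. In this assay the expected step of an at least 1.3-fold lower number from compound 3 to compound 4 (0.12 log units; that floor lies within the scatter) is small, towards slower removal, and may stay within the scatter. Compound 4 is estimated to give 75 mL.min-1.g-1 (range 30 mL.min-1.g-1 to 180 mL.min-1.g-1).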

Compound 4, intrinsic clearance in microsomes: > 100 mL.min-1.g-1
Compound 4 gave a limit, no number; the forecaster's own chance of this, stated with the estimate: 30%; middle value at least 1.3-fold (0.12 log units) from the limit.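

For the compounds shown here, compound 3 and compound 4 both give only a limit, not a number, in this assay so no step between them can be read: the limit of > 100 mL.min-1.g-1 in this assay, at which 3 of the 4 values shown sit. From the compounds shown here alone, how far the new group on the sulfonyl sulfur changes removal stays open.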